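The source may report more compounds than this note shows. Statements on the series, on what has been measured and on what is new or still open speak of the compounds shown alone.

Measured so far:
- Compound 1, `CN(C)CCC(=O)c1cc2ccc(O)cc2oc1=O`: 71400 nM in an assay on cells for inhibition of Amine oxidase [flavin-containing] B (Homo sapiens), read by fluorescence, spectrophotometry and Amplex Red, with stated times of 60 min and 30 min; on this read-out higher numbers stand for weaker inhibition and lower numbers for stronger inhibition
- Compound 2, `O=C(CCN1CCCC1)c1cc2ccc(O)cc2oc1=O`: > 200000 nM in this assay

Two compounds share one core and differ only in the amine at the end of the chain. Compound 1 carries a dimethylamino group and gives a measured number in this assay. Compound 2 carries a pyrrolidin-1-yl group, and for compound 2 this assay reports only a limit, > 200000 nM, not a number. For the measured compounds named here, the one measured step, an at least 2.8-fold higher number from compound 1 to compound 2 (0.44 log units; beyond the scatter), therefore points toward weaker inhibition when the open-chain amine is closed into a five-membered ring, and its true size is unknown because of the limit of > 200000 nM in this assay, at which 1 of the 2 values shown sits.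

Compound 3, `O=C(CCN1CCCCC1)c1cc2ccc(O)cc2oc1=O`, has not been measured. It differs from compound 2 in one place: piperidin-1-yl in place of pyrrolidin-1-yl on a saturated chain carbon, two bonds along the chain from a carbonyl carbon. Going by the values given here, the only step that bears on this change is the one from compound 1 to compound 2, which already ran out of the measurable range. Enlarging the ring by one carbon is expected to leave compound 3 at or beyond that same limit, so the expected step that the limit leaves unreadable from compound 2 to compound 3 is none beyond the scatter or a further weakening. Compound 3 is estimated at 300000 nM, within 100000 nM to 1000000 nM.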

Compound 3, half-maximal inhibitory concentration: > 200000 nM
Compound 3 was reported as a limit; the forecaster's own chance of this, stated with the estimate: 75%; the middle value is on the limit's open side.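

In this assay, the result for compound 3 is a limit and not a number, so the pyrrolidin-1-yl ring is no longer the only ring amine at this position to give no measured value. The comparison with the open-chain dimethylamino group gives an at least 2.8-fold higher number from compound 1 to compound 3 (0.44 log units; beyond the scatter), which shows that the weakening seen with the five-membered ring also holds for the six-membered piperidin-1-yl ring. The step between the two ring amines cannot be read, and how far either ring compound really lies from compound 1 stays unknown, because both ring compounds are reported only as a limit: the limit of > 200000 nM in this assay, at which 2 of the 3 values shown sit.

The compounds shown leave open whether the loss follows from closing the amine into a ring or whether other amines would behave the same way, such as the open-chain diethylamino group or the morpholin-4-yl ring, which carries an oxygen in the ring. They also leave open whether a longer chain between the carbonyl and the amine would bring the pyrrolidin-1-yl and piperidin-1-yl compounds back into the measurable range.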